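This account rests on a few compounds, and the source may have more. Where it says the series, first, only, none or still open, it means among the compounds named here.

Compound 1, `Cc1c(C(=O)N/N=C/c2ccc(C(F)(F)F)cc2)no[n+]1[O-]`, was tested in an ADME assay on J744 cells (Mus musculus) for cytotoxicity, read by MTT assay, with a stated time of 48 h; a higher number here means a weaker inhibitor, a lower number a stronger inhibitor. In this assay compound 1 gives only the limit of the measurement, > 400000 nM, so no true number for it is known. Compound 2, `Cc1c(C(=O)N/N=C/c2ccco2)no[n+]1[O-]`, likewise gives only the limit > 400000 nM in this assay. Compound 3, `Cc1nc2ccccn2c1C(=O)N/N=C/c1ccc2no[n+]([O-])c2c1`, also gives only the limit > 400000 nM in this assay. Compound 1 therefore stands where every measured compound stands, at the limit of > 400000 nM in this assay, at which 3 of the 3 values shown sit: none of the three harms these cells strongly enough for a number to be read.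

Compound 4, `Cc1c(C(=O)N/N=C/c2ccc(Br)cc2)no[n+]1[O-]`, has not yet been measured. It differs from compound 1 in one place: bromo in place of trifluoromethyl on an aromatic carbon. Within the data shown here, no step between two measured compounds is available to show what such a change does in this assay. Because compound 1 gives only the limit > 400000 nM, compound 4 is expected to give a limit as well. The expected step of a number no higher from compound 1 to compound 4 (the limit leaves the size open) is about none beyond the usual scatter. For compound 4 the estimated value in this assay is 400000 nM, with a range from 150000 nM to 1500000 nM.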

Compound 4, half-maximal inhibitory concentration: 162000 nM
Compound 4: middle estimate off by 2.5-fold (0.39 log units), on the high side, and the stated range covers the measured number.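

Bromo in place of trifluoromethyl on this aromatic carbon gives an at least 2.4-fold lower number from compound 1 to compound 4 (0.39 log units; beyond the scatter), so a change at this one place can bring a reading within the measurable range of this assay. Going by these compounds, one end of this step is a limit, so only its smallest possible size is known, and the true size remains open. Compound 4 is also the only compound shown that gives a real number, which makes it the first point in this series that later compounds can be compared with directly, rather than one more result at the limit: the limit of > 400000 nM in this assay, at which 3 of the 4 values shown sit.

On these data alone, whether another group at this place, such as chloro, an amine or a carboxylic acid, would also lower the number remains open. As far as these compounds go, it is equally open whether the same swap would lower the number on a different core.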